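Methoxy for Methyl on the Sulfonyl Ring

A few compounds are considered here, and "the series" means these few. Any claim that something is new, unique, unknown or untested is made for them only; others in the source may bear on it.

Two compounds carry measurements here. In a functional assay on the whole organism (strain Kunming) for inhibition, with Mus musculus as the target, with a stated time of 1 h, at a dose of 40 mg/kg by the oral route (on this read-out higher numbers stand for more inhibition at the one dose given (going by the name of the read-out) and lower numbers for less inhibition), compound 1 `Cc1ccc(N2CCN(c3ccc(C(=O)/C=C/c4ccccc4)cc3)CC2)cc1` gives 2.85%, while compound 2 `Cc1ccc(S(=O)(=O)N2CCN(c3ccc(C(=O)/C=C/c4ccccc4)cc3)CC2)cc1` gives 30.8%. Among the measured compounds shown here, the single change between them, (4-methylphenyl)sulfonyl in place of 4-methylphenyl on an amine nitrogen in a ring, brings a number 28 percentage points higher from compound 1 to compound 2 (beyond the scatter). Compound 2 therefore stands highest of the two numbers in this assay, with compound 1 as the nearest number, lower and beyond the scatter.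

Compound 3 `COc1ccc(S(=O)(=O)N2CCN(c3ccc(C(=O)/C=C/c4ccccc4)cc3)CC2)cc1` differs from compound 2 in one place: methoxy in place of methyl on an aromatic carbon. Put one bond further out, (4-methylphenyl)sulfonyl becomes (4-methoxyphenyl)sulfonyl. For the measured compounds named here, no measured step covers a change of this kind; the only known step alters the group on the amine nitrogen in a ring, not a substituent on its aromatic ring, so it offers no guide to direction or size. Close to the value of compound 2 is where compound 3 is expected, at an estimated 30%, with a range from 10% to 50%. The step this estimate means, a number 0.8 percentage points lower from compound 2 to compound 3 (within the scatter), is expected to lie within the usual scatter.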

Compound 3, a percentage reported as inhibition, in the whole organism at one dose (the size of the read-out at that dose, not a potency): 45.2%
Compound 3: the middle estimate sits 15.2 percentage points below what was measured; the range from low to high includes it.
By their numbers in this assay, from the lowest: compound 1; then compound 2; then compound 3.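

In this assay, the substituent on the aromatic ring of the sulfonyl group proves able to shift the read-out: methoxy in place of methyl, para to a large group, gives a number 14.4 percentage points higher from compound 2 to compound 3 (beyond the scatter) and so goes beyond the usual scatter. The earlier compounds shown here had tested only the group on the ring nitrogen, whereas this step shows that the far end of that group matters too, and the full change to (4-methoxyphenyl)sulfonyl in place of 4-methylphenyl gives a number 42.4 percentage points higher from compound 1 to compound 3 (beyond the scatter) as the largest step seen so far. Nothing at hand explains the gain from methoxy.

On these data alone, whether other groups at this place, such as a chlorine atom, an amine or a longer alkoxy chain, would raise the number further remains open. So does the question of whether methoxy would give a similar step elsewhere on that ring.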